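Replacing 2,3-dichlorophenyl with 4-chlorophenyl in compound 2

This account rests on a few compounds, and the source may have more. Where it says the series, first, only, none or still open, it means among the compounds named here.

Among the measured compounds shown here, in a functional assay (strain AB) with Danio rerio as the target, read by microscopy, with a stated time of 1 h (on this read-out higher numbers stand for an effect only at larger amounts of compound and lower numbers for an effect already at smaller amounts), compound 2 (`CCN1CCc2c(sc(NC(=O)Nc3cccc(Cl)c3Cl)c2C(N)=O)C1`) gives 17400 nM as the highest of the three numbers so far. Compound 3 (`CCN1CCc2c(sc(NC(=S)Nc3ccc(Cl)cc3)c2C(N)=O)C1`) gives 6570 nM and compound 1 (`CC(C)(C)OC(=O)CCCC[N+]1(C)CCc2c(sc(NC(=O)Nc3ccc(Cl)cc3)c2C(N)=O)C1`) gives 140 nM and both lie below compound 2 beyond the scatter. Compound 4 (`CCN1CCc2c(sc(NC(=O)Nc3ccc(Cl)cc3)c2C(N)=O)C1`) carries 4-chlorophenyl in place of 2,3-dichlorophenyl on an amide-type nitrogen. For the measured compounds named here, no measured pair differs in this one place, so the expectation in this assay is indirect. Compound 3 also holds 4-chlorophenyl, and its 6570 nM points to a lower number beyond the scatter. The estimated step is a 5.8-fold lower number from compound 2 to compound 4 (0.76 log units; beyond the scatter) in size. For compound 4 the estimate is 3000 nM with an expected range of 700 nM to 12000 nM in this read-out.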

Compound 4, half-maximal effective concentration: 3120 nM
For compound 4 the middle estimate is 1.0-fold (0.02 log units) below the measured one; low and high end bracket the measured number.
By their numbers in this assay, from the lowest: compound 1; then compound 4; then compound 3; then compound 2.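

In this assay, among the compounds shown here, the group on the amide-type nitrogen now has a direct reading, with 4-chlorophenyl in place of 2,3-dichlorophenyl giving a 5.6-fold lower number from compound 2 to compound 4 (0.75 log units; beyond the scatter) as the only change to the structure. This shows that the number responds to the aryl group at this position, but the step alters the chlorine count and placement together, and this single pair cannot separate the two. Nothing at hand bears on the cause of this step. Open, on these data alone, is how a plain phenyl without chlorine would compare with compound 4 at this position. Also open, as far as these compounds go, is whether a methoxyphenyl group would continue the same direction.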